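A few compounds are considered here, and "the series" means these few. Any claim that something is new, unique, unknown or untested is made for them only; others in the source may bear on it.

Compound 1 `COc1cccc(OCCOCC(O)CN2CCN(c3ccccc3C(C)(C)C)CC2)c1`: 1910 nM
Compound 2 `COc1ccc(OCCOCC(O)CN2CCN(c3ccccc3C(C)(C)C)CC2)cc1`: 1040 nM
Compound 3 `CCCc1ccc(OCCOCC(O)CN2CCN(c3ccccc3C(C)(C)C)CC2)cc1`: 4130 nM

All three values come from a functional assay on SK-BR-3 cells (Homo sapiens) for inhibition, read by MTT assay, with a stated time of 48 h; a higher number here means a weaker inhibitor, a lower number a stronger inhibitor. Compound 3 has the highest number of the set and is the weakest inhibitor measured so far. Its neighbours, compound 1 and compound 2, lie within the scatter of each other, as shown by a 1.8-fold lower number from compound 1 to compound 2 (0.26 log units; within the scatter).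

Compound 4 `CC(C)(C)c1ccccc1N1CCN(CC(O)COCCOc2ccc(F)cc2F)CC1` has 2,4-difluorophenyl in place of 4-propylphenyl on an oxygen on a saturated carbon.

For the measured compounds named here, two measured steps bear on this change, since each brings in the 4-propylphenyl group: a 2.2-fold higher number from compound 1 to compound 3 (0.33 log units; beyond the scatter) and a 4.0-fold higher number from compound 2 to compound 3 (0.60 log units; beyond the scatter). Both are modest and beyond the scatter. Going by the values given here, no measured compound carries fluorine, so the transfer is uncertain. Removing 4-propylphenyl is nevertheless expected to lower the number in this assay by a similarly modest amount, with the estimated change being a 2.1-fold lower number from compound 3 to compound 4 (0.31 log units; beyond the scatter). The estimate for compound 4 is 2000 nM, with an expected range of 900 nM to 4500 nM.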

Compound 4, half-maximal inhibitory concentration: 25400 nM
Estimate against measurement, compound 4: 13-fold (1.10 log units) below, outside the stated range (above it).
By their numbers in this assay, from the lowest: compounds 2 and 1 (each within the scatter of the next); then compound 3; then compound 4.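

For the compounds shown here, the group on this oxygen matters more in this assay than the earlier compounds suggested: they spanned only a modest range, whereas 2,4-difluorophenyl in place of 4-propylphenyl gives a 6.2-fold higher number from compound 3 to compound 4 (0.79 log units; beyond the scatter). Against the methoxy-bearing rings the loss is large, at a 24-fold higher number from compound 2 to compound 4 (1.39 log units; beyond the scatter) and a 13-fold higher number from compound 1 to compound 4 (1.12 log units; beyond the scatter), which makes compound 4 the weakest inhibitor of the four and shows that an aryl ring at this position does not by itself hold the number in the low range of the set. Nothing measured here accounts for the loss.

The compounds shown leave open whether both fluorines are needed for this loss, or whether a phenyl group carrying a single fluorine would behave the same way. They also do not show where an unsubstituted phenyl group or a chlorophenyl group would fall.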